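Swapping the alkyne aryl group in an amide series

The source may hold more compounds than are shown below. What is called first, only, known or untested is meant among the compounds shown, and "the series" means these compounds.

Measured compounds:
Compound 1, `C[C@H](NC(=O)c1ccc(C#Cc2cccc(F)c2)cn1)C(C)(C)C`, gives 70.8% in a functional assay on HEK293 cells for positive allosteric modulation of metabotropic glutamate receptor 5 (Rattus norvegicus), read by fluorescence and calcium flux; a lower number here means a smaller maximal response, a higher number a larger maximal response.
Compound 2, `CC(C)[C@@H](C)NC(=O)c1ccc(C#Cc2cccc(F)c2)cn1`, gives 69.3% in this assay.
Compound 3, `O=C(NCC1CC1)c1ccc(C#Cc2cccc(F)c2)cn1`, gives 61.4% in this assay.

All three compounds share a core in which an amide carries a varied group on its nitrogen, while an alkyne links the core to a 3-fluorophenyl ring. Compound 2 sits in the middle of the three numbers, yet all three lie within the usual scatter of one another: the nearest value is that of compound 1 (a number 1.5 percentage points lower from compound 1 to compound 2 (within the scatter)), the furthest that of compound 3 (a number 7.9 percentage points lower from compound 2 to compound 3 (within the scatter)). The third step, a number 9.4 percentage points lower from compound 1 to compound 3 (within the scatter), is likewise within the scatter. So far the numbers show that exchanging groups on the amide-type nitrogen has not moved the maximal response beyond noise.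

Compound 4, `CC(C)[C@@H](C)NC(=O)c1ccc(C#Cc2ccccn2)cn1`, differs from compound 2 in another place: pyridin-2-yl in place of 3-fluorophenyl on a triple-bonded carbon. None of the three measured steps touches this part of the molecule; they all concern the amide-type nitrogen. Within the data shown here, there is therefore no measured step that bears directly on this change, and the only guide is that the series so far has moved little at all.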

Compound 4, largest response reached (reported as efficacy), in percent of the reference or control that the assay uses: 58.5%
Estimate against measurement, compound 4: 9.5 percentage points above; the range from low to high includes it.
By their numbers in this assay, from the lowest: compounds 4, 3, 2 and 1 (each within the scatter of the next, the first and the last beyond it).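

In this assay, the aryl group on the alkyne is the only place among those shown where a single exchange moves the maximal response past the usual scatter: pyridin-2-yl in place of 3-fluorophenyl on a triple-bonded carbon gives a number 10.8 percentage points lower from compound 2 to compound 4 (beyond the scatter) while the three steps on the amide-type nitrogen all stayed within the scatter. The group on the amide nitrogen is identical in the two compounds, which makes this a clean comparison of one ring for another: a ring of carbon only that bears fluorine leaves, and a ring holding one nitrogen, counted as a hydrogen-bond acceptor, enters. Nothing measured here explains why the number falls, and this one step cannot separate losing the fluorine from gaining the ring nitrogen.

A plain phenyl group on the same triple-bonded carbon would help to pull those two parts of the exchange apart. Also open, as far as these compounds go, is whether pyridin-2-yl gives a step of similar size when the amide nitrogen carries 1,2,2-trimethylpropyl or cyclopropylmethyl instead of 1,2-dimethylpropyl.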